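Fluoro to Trifluoromethyl in Two Cytotoxicity Series

The compounds below may be only part of what the source reports. "The series", "measured", "known", "first", "only" and "open" are said of these compounds alone.

Compound 1, `CC(=O)Nc1ccc(O)c(C(=O)/C=C/c2ccc(F)cc2)c1`: 41100 nM
Compound 2, `CC(=O)Nc1ccc(O)c(C(=O)/C=C/c2ccc(C(F)(F)F)cc2)c1`: 21100 nM
Compound 3, `COc1c(-c2ccc(F)cc2)oc2ccc(N)cc2c1=O`: 141000 nM

All three were tested in an ADME assay on MT4 cells (Homo sapiens) for cytotoxicity, read by MTT assay, with a stated time of 4 days; a higher number here means that more compound is tolerated, a lower number that less compound is tolerated. Compound 1 gives 41100 nM, while compound 2 gives 21100 nM. The two differ only by trifluoromethyl in place of fluoro on an aromatic carbon, and this change made a step of a 1.9-fold lower number from compound 1 to compound 2 (0.29 log units; within the scatter).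

Compound 3 rests on a different core; how its core differs from that of compound 1 is not broken down here. In this assay compound 3 gives 141000 nM, the highest of the three values.

Compound 4, `COc1c(-c2ccc(C(F)(F)F)cc2)oc2ccc(N)cc2c1=O`, has not yet been measured. It differs from compound 3 by trifluoromethyl in place of fluoro on an aromatic carbon, which is the same change as that from compound 1 to compound 2. Because that earlier change gave a 1.9-fold lower number from compound 1 to compound 2 (0.29 log units; within the scatter), a step of similar size, a 1.9-fold lower number from compound 3 to compound 4 (0.28 log units; within the scatter), is expected here, though the different core leaves the outcome uncertain. Compound 4 is therefore estimated at 74000 nM, with a likely range from 35000 nM to 150000 nM.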

Compound 4, half-maximal cytotoxic concentration: 290000 nM
Compound 4: middle estimate off by 3.9-fold (0.59 log units), on the low side; measured number outside the range, above it.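

In this assay, trifluoromethyl in place of fluoro gave a 2.1-fold higher number from compound 3 to compound 4 (0.31 log units; beyond the scatter), so on the core of compound 3 the change went the opposite way to what the core of compound 1 suggested. This shows that, in this series, the result of the change cannot simply be carried from one core to the other, since the two steps stand further apart than repeated measurements would usually explain: the same change on two cores in this assay, a 1.9-fold lower number (0.29 log units; within the scatter) from compound 1 to compound 2 and a 2.1-fold higher number (0.31 log units; beyond the scatter) from compound 3 to compound 4, 4.0-fold (0.60 log units) apart, beyond the scatter of two such steps

It does not show why the cores differ, and with a single pair on each core, one of them a step within the scatter, it gives no general rule for either core.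

What the compounds shown leave open is whether a chloro group, a methoxy group or a nitrile at the same place would follow the step on each core. They also leave open whether the gap between the cores would persist if the amine of compound 3 were replaced by the acetamide carried by compound 1.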